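The source may report more compounds than this note shows. Statements on the series, on what has been measured and on what is new or still open speak of the compounds shown alone.

Within the data shown here, compound 1 `O=C(NC[C@@H]1C[C@@H]2C=C[C@@H]1C2)NS(=O)(=O)N1CCC(CCNC(=O)c2cnsc2)CC1` is one of three compounds measured in a functional assay on the whole organism (blood) with Rattus norvegicus as the target, with stated times of 24 h and 1 h, at a dose of 15 mg/kg by the intraperitoneal route; a higher number here means a stronger effect of the compound at the dose given, a lower number a weaker effect. Compound 1 gives 14%, the lowest of the three numbers. Compound 2 `Cn1cc(C(=O)NCCC2CCN(S(=O)(=O)NC(=O)NC3CCCCC3)CC2)c(=O)n(C)c1=O` gives 15%, within the scatter of compound 1, while compound 3 `O=C(NC[C@@H]1C[C@@H]2C=C[C@@H]1C2)NS(=O)(=O)N1CCC(CCNC(=O)c2cc(Cl)ccn2)CC1` gives 46%, where a number 32 percentage points higher from compound 1 to compound 3 (beyond the scatter). The unmeasured compound 4 `Cn1cc(C(=O)NCCC2CCN(S(=O)(=O)NC(=O)NC[C@@H]3C[C@@H]4C=C[C@@H]3C4)CC2)c(=O)n(C)c1=O` differs from compound 1 as follows: a group of 10 heavy atoms (6 carbon, 2 nitrogen, 2 oxygen; one six-membered aromatic ring with 2 hetero atoms) in place of a group of 5 heavy atoms (3 carbon, 1 nitrogen, 1 sulfur; one five-membered aromatic ring with 2 hetero atoms), on a carbonyl carbon. Among the measured compounds shown here, no measured step bears directly on this change. Compound 2 carries the same entering group on the carbonyl carbon, with a different urea substituent, and its value sits close to compound 1. The expected step of a number 4 percentage points higher from compound 1 to compound 4 (within the scatter) is therefore small and within the scatter. Compound 4 is estimated at 18%, with a range from 5% to 35%.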

Compound 4, a percentage reported as activity, at one dose (the size of the read-out at that dose, not a potency): 32%
For compound 4 the middle estimate is 14 percentage points below the measured one, and the stated range covers the measured number.
By their numbers in this assay, from the lowest: compounds 1 and 2 (each within the scatter of the next); then compound 4; then compound 3.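

On the carbonyl carbon, the entering group of compound 4 is not interchangeable with 1,2-thiazol-4-yl, with a number 18 percentage points higher from compound 1 to compound 4 (beyond the scatter), yet it falls short of 4-chloropyridin-2-yl, with a number 14 percentage points lower from compound 3 to compound 4 (beyond the scatter). The group on the amide-type nitrogen also counts, with a number 17 percentage points higher from compound 2 to compound 4 (beyond the scatter), so the closeness of compounds 1 and 2 did not mean that the entering group leaves this assay unchanged. Nothing available explains these steps. The compounds shown leave open how a simple phenyl ring or a primary amine on the carbonyl carbon would compare.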